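The source may hold more compounds than are shown below. What is called first, only, known or untested is meant among the compounds shown, and "the series" means these compounds.

The measured compounds:
Compound 1 `N#CC1=C(N)Oc2c(c3nc4ccccc4nc3c3ccccc23)C12C(=O)N(Cc1cnnn1-c1ccc(F)cc1)c1ccccc12` — in an ADME assay on HUVEC cells (Homo sapiens) for antiproliferative activity, read by MTT assay, with a stated time of 48 h (a lower number here means a stronger inhibitor, a higher number a weaker inhibitor), compound 1 gives > 50000 nM, which is a limit of the assay rather than a number.
Compound 2 `COc1ccccc1-n1nncc1CN1C(=O)C2(C(C#N)=C(N)Oc3c2c2nc4ccccc4nc2c2ccccc32)c2ccccc21` — in this assay compound 2 gives > 50000 nM, again a limit.
Compound 3 `Cc1ccc(-n2nncc2CN2C(=O)C3(C(C#N)=C(N)Oc4c3c3nc5ccccc5nc3c3ccccc43)c3ccccc32)cc1C` — in this assay compound 3 gives > 50000 nM, also a limit.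

Where compound 1 stands is thus known only as a limit: its true value lies somewhere past the highest concentration tested, and the same holds for the two others. The three compounds share one core and differ only in the group carried on an aromatic nitrogen. The step that the two limits leave unreadable from compound 1 to compound 2 and the step that the two limits leave unreadable from compound 1 to compound 3 cannot be read as numbers, and neither can a step that the two limits leave unreadable from compound 2 to compound 3, since (the limit of > 50000 nM in this assay, at which 3 of the 3 values shown sit).

Compound 4 `N#CC1=C(N)Oc2c(c3nc4ccccc4nc3c3ccccc23)C12C(=O)N(Cc1cnnn1-c1ccc(F)c(Cl)c1)c1ccccc12` differs from compound 1 by one heavy atom: chloro in place of hydrogen on an aromatic carbon. Among the measured compounds shown here, no measured step touches this change directly, and the three that exist yield no size at all. With every measured value resting at the limit, compound 4 is expected to rest there as well, so the step that the limit leaves unreadable from compound 1 to compound 4 is expected to be nothing readable. The estimate for compound 4 in this assay is 60000 nM, ranging from 25000 nM to 150000 nM, and the assay is expected most likely to report only a limit once more.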

Compound 4, half-maximal inhibitory concentration: > 50000 nM
Compound 4 ended at the assay's limit; the forecaster's own chance of this, stated with the estimate: 85%; the middle value is on the limit's open side.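

The new result for compound 4 in this assay is again only a limit, so none of its steps from compound 1, compound 2 or compound 3 can be read: the limit of > 50000 nM in this assay, at which 4 of the 4 values shown sit.

The compounds shown leave open how far each true value lies past that limit, and whether changing the group on the aromatic nitrogen makes any difference in this assay.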